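Working notes: from compound 1 to compound 4

A few compounds are considered here, and "the series" means these few. Any claim that something is new, unique, unknown or untested is made for them only; others in the source may bear on it.

Values from an ADME assay on microsomes from liver (Rattus norvegicus) for metabolic stability, read by LC-MS, using NADPH, at 37 degrees C (a lower number here means that the compound disappears faster, a higher number that the compound lasts longer), so far:
- compound 1 `Cc1ccccc1-c1nc(CN2CCC(C(=O)NCCCN3CCC(C)CC3)CC2)c(C)o1` gives > 0.5 h (a limit of the assay, not a number)
- compound 2 `Cc1ccccc1-c1nc(CN2CCC(C(=O)NCCCN3CCCC(C(C)C)C3)CC2)c(C)o1` gives 0.323 h
- compound 3 `Cc1ccccc1-c1nc(CN2CCC(C(=O)NCCCN3CCCC(CC(C)C)C3)CC2)c(C)o1` gives 0.0383 h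

Compound 1 stands at a limit and has no number (the limit of > 0.5 h in this assay, at which 1 of the 3 values shown sits). Compound 4 `Cc1ccccc1-c1nc(CN2CCC(C(=O)N3CCN(CCN(C)C)CC3)CC2)c(C)o1` departs from compound 1 in the group on a carbonyl carbon (a group of 11 heavy atoms (8 carbon, 3 nitrogen; one six-membered non-aromatic ring with 2 hetero atoms) in place of a group of 11 heavy atoms (9 carbon, 2 nitrogen; one six-membered non-aromatic ring with 1 hetero atom), on a carbonyl carbon). The group that enters is 4-(2-(dimethylamino)ethyl)piperazin-1-yl.

For the measured compounds named here, three measured steps bear on this, all within the group that leaves. The first (an at least 1.5-fold lower number from compound 1 to compound 2 (0.18 log units; that floor lies within the scatter)) has a floor within the scatter. The second (an at least 13-fold lower number from compound 1 to compound 3 (1.11 log units; beyond the scatter)) is large and the third (an 8.4-fold lower number from compound 2 to compound 3 (0.93 log units; beyond the scatter)) is modest, both beyond the scatter. None of them replaces the whole group, so they guide only loosely. The two larger steps both end on the isobutyl group of compound 3, which compound 4 does not carry, so a fall of that size is not expected. The expected change in this assay is no step beyond the scatter (an at least 1.2-fold lower number from compound 1 to compound 4 (0.09 log units; that floor lies within the scatter)). For compound 4 the estimate is 0.4 h with an expected range from 0.13 h to 1 h in this read-out.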

Compound 4, half-life: > 0.5 h
Compound 4 gave a limit, no number; the forecaster's own chance of this, stated with the estimate: 35%; middle value at least 1.2-fold (0.09 log units) away from the limit.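

No step can be read between compound 1 and compound 4, as each stands at a limit of the assay and not at a number: the limit of > 0.5 h in this assay, at which 2 of the 4 values shown sit.

Going by these compounds, whether the 4-(2-(dimethylamino)ethyl)piperazin-1-yl group changes the half-life relative to compound 1, and by how much, stays open.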